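The compounds below may be only part of what the source reports. "The series", "measured", "known", "first", "only" and "open" are said of these compounds alone.

Of the compounds shown here, three have so far been measured in a functional assay on HepG2 cells (Homo sapiens) for antiproliferative activity, read by MTT assay, with a stated time of 48 h; a higher number here means a weaker inhibitor, a lower number a stronger inhibitor. Compound 1 `Clc1ccc(CSc2nnc(-c3cnccn3)s2)cc1` gives 6230 nM, while compound 2 `Brc1ccc(CSc2nnc(-c3cnccn3)s2)cc1` gives 780 nM. The change between them is bromo in place of chloro on an aromatic carbon, and it produced an 8.0-fold lower number from compound 1 to compound 2 (0.90 log units; beyond the scatter). Compound 3 `Clc1ccc(CSc2nnc(-c3cnccn3)n2-c2ccccc2)cc1` has a different core from compound 1; the difference between the two cores is not broken down here. In this assay compound 3 gives 15300 nM, the highest of the three numbers, standing beyond the scatter from compound 1 and further still from compound 2.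

Compound 4 `Brc1ccc(CSc2nnc(-c3cnccn3)n2-c2ccccc2)cc1` has not yet been measured. It differs from compound 3 by bromo in place of chloro on an aromatic carbon, the same change that separates compound 2 from compound 1, at a place described in the same words. Among the compounds with values here, the only guide to its size is an 8.0-fold lower number from compound 1 to compound 2 (0.90 log units; beyond the scatter), seen once on the other core. On that basis the step to compound 4 is expected to be a 6.1-fold lower number from compound 3 to compound 4 (0.79 log units; beyond the scatter). Compound 4 is therefore estimated at 2500 nM, with the number expected to fall between 900 nM and 7000 nM.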

Compound 4, half-maximal inhibitory concentration: 11400 nM
Estimate against measurement, compound 4: 4.6-fold (0.66 log units) below; measured number above the stated range.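

In this assay, bromo in place of chloro on the core of compound 3 gave a 1.3-fold lower number from compound 3 to compound 4 (0.13 log units; within the scatter), so the large step seen on the core of compound 1 did not carry over in size: the same change on two cores in this assay, an 8.0-fold lower number (0.90 log units; beyond the scatter) from compound 1 to compound 2 and a 1.3-fold lower number (0.13 log units; within the scatter) from compound 3 to compound 4, 6.0-fold (0.77 log units) apart, beyond the scatter of two such steps

The same change therefore cannot be treated as a fixed increment across these two cores, and a step read on one of them proved a poor guide to the step on the other. Within the data shown here, with only one pair on each core, this does not show which feature of the cores sets the two steps apart, nor how the change would behave on any third core.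

From the compounds shown here alone, whether fluoro, methoxy or an amine in place of bromo would also separate the two cores remains open. So does the question of whether the difference between the steps would persist with a longer chain in place of the 4-bromobenzyl group.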